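This account rests on a few compounds, and the source may have more. Where it says the series, first, only, none or still open, it means among the compounds named here.

Compounds measured so far:
Compound 1, `COc1ccc(-c2nc(SCC(=O)c3sc(-c4ccccc4)nc3C)[nH]c(=O)c2C#N)cc1`, 48400 nM
Compound 2, `Cc1nc(-c2ccccc2)sc1C(=O)CSc1nc(N)c(C#N)c(-c2ccc(Cl)cc2)n1`, 10800 nM
Compound 3, `COc1ccc(-c2nc(SCC(=O)c3sc(-c4ccc(Cl)cc4)nc3C)[nH]c(=O)c2C#N)cc1`, 35500 nM

In a functional assay on U-87MG ATCC cells for antiproliferative activity against U-87 MG (Homo sapiens), read by MTT assay, with a stated time of 48 h (on this read-out higher numbers stand for weaker inhibition and lower numbers for stronger inhibition), compound 2 gives the lowest number of the three; compound 3 sits a 1.4-fold lower number from compound 1 to compound 3 (0.13 log units; within the scatter) lower than compound 1, a step the data mark as within the scatter. How the core of compound 2 differs from the core of compound 1 is not broken down here. The change from compound 1 to compound 3 is chloro in place of hydrogen on an aromatic carbon, and the same change is made from compound 2 to the unmeasured compound 4, `Cc1nc(-c2ccc(Cl)cc2)sc1C(=O)CSc1nc(N)c(C#N)c(-c2ccc(Cl)cc2)n1`: chloro in place of hydrogen on an aromatic carbon. Across the compounds shown this change occurs twice, once measured and once awaiting a result. Since compound 3 moved only a 1.4-fold lower number from compound 1 to compound 3 (0.13 log units; within the scatter) from compound 1, the step from compound 2 to compound 4 in this assay is expected to be of similar size, a 1.4-fold lower number from compound 2 to compound 4 (0.13 log units; within the scatter), resting on that single measured pair. Compound 4 is therefore estimated at 8000 nM, with a likely range from 3500 nM to 20000 nM.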

Compound 4, half-maximal inhibitory concentration: 3420 nM
Beside the measured number, compound 4's estimate is 2.3-fold (0.37 log units) above it; the measured number lies below the stated range.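

In this assay, the change from phenyl to 4-chlorophenyl gives a 3.2-fold lower number from compound 2 to compound 4 (0.50 log units; beyond the scatter), a modest step that lies beyond the scatter. Set beside the earlier step on the core of compound 1, the two cannot be told apart: the same change on two cores in this assay, a 1.4-fold lower number (0.13 log units; within the scatter) from compound 1 to compound 3 and a 3.2-fold lower number (0.50 log units; beyond the scatter) from compound 2 to compound 4, 2.3-fold (0.36 log units) apart, within the scatter of two such steps This fits a change that carries over between these two cores with a step of comparable size, but it rests on only two pairs and shows neither that the size is fixed nor that it would hold on any other core.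

The compounds shown leave open whether fluoro, bromo or trifluoromethyl in the same place would give a step like that of chloro. They also leave open how the change would read on a core carrying a carboxylic acid or a longer chain.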